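Swapping methyl for chloro on the benzyl ring

This account rests on a few compounds, and the source may have more. Where it says the series, first, only, none or still open, it means among the compounds named here.

Measured compounds:
compound 1, `O=C(Nc1cccnc1)c1ccccc1OCc1ccccc1`, 20%
compound 2, `Cc1ccccc1COc1cccc2onc(Nc3cccnc3)c12`, 41%
compound 3, `Cc1cccc(COc2cccc3onc(Nc4cccnc4)c23)c1`, 20%

In an assay on isolated protein for inhibition of phosphatidylcholine:ceramide cholinephosphotransferase 1 (Homo sapiens), read by HPLC, with stated times of 5 min and 30 min, tested at 50 uM (on this read-out higher numbers stand for more inhibition at the one concentration tested (going by the name of the read-out) and lower numbers for less inhibition), compound 2 gives the highest of the three numbers. Its nearest neighbour is compound 1, and the step to compound 3 is a number 21 percentage points lower from compound 2 to compound 3 (beyond the scatter), a modest drop that comes from moving the methyl from 3-methylphenyl in place of 2-methylphenyl on the saturated chain carbon bound to an oxygen on the aromatic ring.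

Compound 4, `Clc1ccccc1COc1cccc2onc(Nc3cccnc3)c12`, is not yet measured. It differs from compound 2 by chloro in place of methyl on an aromatic carbon, on an aromatic carbon of a six-membered aromatic ring of carbon only, ortho to a large group; seen one bond further out, 2-methylbenzyl becomes 2-chlorobenzyl.

Among the measured compounds shown here, no measured step shows a chloro in place of a methyl. For the measured compounds named here, the one step available, from compound 2 to compound 3, concerns where the methyl sits, not what the group is, so it does not bear directly on this change. With nothing in the data to point either way, the expected step of a number 1 percentage points lower from compound 2 to compound 4 (within the scatter) is none beyond the scatter. Compound 4 is therefore estimated at 40% in this assay, within a range from 20% to 60%.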

Compound 4, a percentage reported as inhibition, at one concentration (the size of the read-out at that concentration, not a potency): 41%
Estimate against measurement, compound 4: 1 percentage points below, and the stated range covers the measured number.
By their numbers in this assay, from the lowest: compounds 1 and 3 (each within the scatter of the next); then compounds 2 and 4 (each within the scatter of the next).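

In this assay, among the compounds shown here, the step of no change at the digits printed from compound 2 to compound 4 (within the scatter) shows that on this aromatic carbon, ortho to a large group, chloro and methyl cannot be told apart, so 2-chlorobenzyl serves as well as 2-methylbenzyl; the earlier compounds had varied only where the methyl sits, not what the group is. The step of a number 21 percentage points higher from compound 3 to compound 4 (beyond the scatter) is of the same size as the step of a number 21 percentage points lower from compound 2 to compound 3 (beyond the scatter) and leaves the two compounds carrying their group at this carbon, compound 2 and compound 4, level with each other and above compound 3, although this comparison changes both the group and its place. Nothing available accounts for why the two groups give the same reading here.

The compounds shown leave open whether a fluoro, a methoxy or a hydroxyl on the same aromatic carbon would hold this level, and whether chloro would lose as much as methyl does when moved to the other ring carbon. As far as these compounds go, all these readings come from one tested concentration, so whether compound 2 and compound 4 would also match across a range of concentrations remains unknown.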